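The source may hold more compounds than are shown below. What is called first, only, known or untested is meant among the compounds shown, and "the series" means these compounds.

Measured so far:
Compound 1, `C#CCN(Cc1ccc2nc(C)nc(O)c2c1)c1ccc(C(=O)N[C@@H](CCC(=O)O)C(=O)NC(C)(C)C(=O)O)cc1`: 42 nM
Compound 2, `C#CCN(Cc1ccc2nc(C)nc(O)c2c1)c1ccc(C(=O)N[C@@H](CCC(=O)O)C(=O)N(C)CC(=O)O)cc1`: 50 nM

Both compounds share the same core and differ only in the group attached to the final carbonyl carbon of the chain. In an assay on L1210 cells for inhibition of Thymidylate synthase (Mus musculus) (a lower number here means a stronger inhibitor, a higher number a weaker inhibitor), compound 2 gives 50 nM, while compound 1 gives 42 nM. Compound 2 holds the higher of the two numbers, but the step of a 1.2-fold higher number from compound 1 to compound 2 (0.08 log units; within the scatter) falls within the scatter, so the two compounds cannot be told apart on these data.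

Compound 3, `C#CCN(Cc1ccc2nc(C)nc(O)c2c1)c1ccc(C(=O)N[C@@H](CCC(=O)O)C(=O)N[C@@H](CCC(=O)O)C(=O)O)cc1`, has not yet been measured in this assay. It differs from compound 2 by (1,3-dicarboxypropyl)amino in place of (carboxymethyl)(methyl)amino on a carbonyl carbon. Within the data shown here, only one measured step touches this position, a 1.2-fold higher number from compound 1 to compound 2 (0.08 log units; within the scatter), and it lies within the scatter: swapping one group for another on this carbonyl carbon changed nothing that can be trusted. Among the measured compounds shown here, no measured pair shows the exchange that leads to compound 3, so its larger change rests on a single uninformative step. The expectation is therefore a step of no more than the scatter, in either direction. Compound 3 is expected to give 35 nM, within a range from 10 nM to 120 nM. That estimate corresponds to an expected step of a 1.4-fold lower number from compound 2 to compound 3 (0.15 log units; within the scatter).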

Compound 3, inhibition constant: 2 nM
Compound 3: the middle estimate sits 18-fold (1.24 log units) above what was measured; measured number below the stated range.
By their numbers in this assay, from the lowest: compound 3; then compounds 1 and 2 (each within the scatter of the next).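

In this assay, among these compounds, the group on this carbonyl carbon proves able to shift the number strongly: replacing (carboxymethyl)(methyl)amino with (1,3-dicarboxypropyl)amino gives a 25-fold lower number from compound 2 to compound 3 (1.40 log units; beyond the scatter), whereas the only earlier step at this position lay within the scatter. The large change also appears as a 21-fold lower number from compound 1 to compound 3 (1.32 log units; beyond the scatter), where 1,3-dicarboxypropyl takes the place of 1-carboxy-1-methylethyl on an amide-type nitrogen, and since compound 1 carries the amide hydrogen just as compound 3 does, that hydrogen alone does not separate the strong inhibitor from the weaker ones. No measurement here explains why the (1,3-dicarboxypropyl)amino group gives this result.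

The entering group differs from both earlier groups in several ways at once, including its second carboxy group, its longer chain and its defined stereocentre, so these compounds cannot show which feature goes with the lower number. Going by these compounds, it remains open whether a single carboxylic acid on a longer chain, an amide in place of either carboxylic acid, or the opposite configuration at the stereocentre would keep the number this low.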